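Aryloxypropoxy spirocyclic guanidines: antiproliferative series notes

The source may report more compounds than this note shows. Statements on the series, on what has been measured and on what is new or still open speak of the compounds shown alone.

Measured compounds:
- compound 1, `NC1=NC2(CCOCC2)N(OCCCOc2ccc(F)cc2)C(N)=N1`: "not determined" (no result reported)
- compound 2, `NC1=NC2(CCOCC2)N(OCCCOc2cc(Cl)c(Cl)cc2Cl)C(N)=N1`: "not determined" (no result reported)
- compound 3, `NC1=NC2(CCOCC2)N(OCCCOc2ccccc2Cl)C(N)=N1`: 1750 nM

For the measured compounds named here, compound 3 is the only compound of the three with a number in a functional assay on HepG2 cells (Homo sapiens) for antiproliferative activity, read by MTT assay, with a stated time of 72 h; on this read-out lower numbers stand for stronger inhibition and higher numbers for weaker inhibition; compound 1 and compound 2 carry no result there, so compound 3 stands alone and no ranking is possible. Compound 4, `NC1=NC2(CCOCC2)N(OCCCOc2cccc(Br)c2)C(N)=N1`, has not been measured in this assay. It differs from compound 3 by 3-bromophenyl in place of 2-chlorophenyl on an oxygen on a saturated carbon. Going by the values given here, no step between two measured compounds is available to calibrate this change, so no direction can be inferred from the data; a step no larger than the usual scatter is expected, a 1.0-fold higher number from compound 3 to compound 4 (0.01 log units; within the scatter). Compound 4 is therefore estimated at 1800 nM in this assay, with a range from 700 nM to 4500 nM.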

Compound 4, half-maximal inhibitory concentration: 320 nM
Compound 4: middle estimate off by 5.6-fold (0.75 log units), on the high side; the measured number lies below the stated range.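

In this assay, 3-bromophenyl in place of 2-chlorophenyl gives a 5.5-fold lower number from compound 3 to compound 4 (0.74 log units; beyond the scatter) and lies beyond the usual scatter. The group on an oxygen on a saturated carbon therefore matters to the read-out, which compound 3 alone could not show. No measured evidence bears on the reason for this step.

The halogen and its place on the ring change together in this one step, so their contributions cannot be separated. As far as these compounds go, whether an amine on the phenyl ring or a longer chain keeps this level of inhibition remains open.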